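This account rests on a few compounds, and the source may have more. Where it says the series, first, only, none or still open, it means among the compounds named here.

Three amides on a shared core have been run in a functional assay on REH cells (Homo sapiens) for inhibition, read by CellTiter-Glo, with a stated time of 72 h (on this read-out lower numbers stand for an effect already at smaller amounts and higher numbers for an effect only at larger amounts of compound), and only one of them returned a number. Compound 1 (`CC1=C(CC(=O)N(C)CCN(C)C)c2cc(F)ccc2/C1=C\c1nc2ccccc2s1`) is recorded as "not active" (no number reported) and compound 2 (`CC1=C(CC(=O)NCCN2CCCC2)c2cc(F)ccc2/C1=C\c1nc2ccccc2s1`) gives 18000 nM as the sole figure in the set. Compound 3 (`CC1=C(CC(=O)N2CCN(CCCN(C)C)CC2)c2cc(F)ccc2/C1=C\c1nc2ccccc2s1`) is recorded as "not active" (no number reported) and so has no single number. It shares that kind of entry with compound 1, and neither can be placed on a scale against compound 2.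

The next compound is compound 4 (`CC1=C(CC(=O)N2CCN(c3ccncc3)CC2)c2cc(F)ccc2/C1=C\c1nc2ccccc2s1`). It carries pyridin-4-yl in place of 3-(dimethylamino)propyl on an amine nitrogen in a ring. The rest of the molecule stays as it is in compound 3.

Compound 3 offers no number from which a step could be counted. The expectation is a modest move towards lower numbers in this assay, enough to yield a measurable value but no more, and a second entry without a number remains quite possible. Among the compounds with values here, the only guide to scale is compound 2 at 18000 nM on the same read-out. In this assay the estimate for compound 4 is an expected 10000 nM within an estimated range from 3000 nM to 30000 nM as the likely span.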

Compound 4, half-maximal effective concentration: "not active" (no number reported)
Compound 4 has no reported number here; the estimate stays without a comparison.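

Compound 3 and compound 4 both lack a single number in this assay, so no step can be read between them. No available evidence bears on this result. The compounds shown leave open whether pyridin-4-yl and 3-(dimethylamino)propyl on the amine nitrogen differ at all in this read-out.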